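The compounds below may be only part of what the source reports. "The series", "measured", "known", "first", "only" and "open" are said of these compounds alone.

Measured so far:

Compound 1 `COc1cc(-c2nn(-c3cccc(NC(=O)Nc4cc(C(F)(F)F)cc(C(F)(F)F)c4)c3)cc2-c2ccncc2)ccc1Cl` gives 3250 nM.
Compound 2 `COc1cc(-c2nn(-c3cccc(NC(=O)c4cccc(C(F)(F)F)c4)c3)cc2-c2ccncc2)ccc1Cl` gives only a limit of the assay, > 50000 nM.
Compound 3 `O=C(Nc1cccc(-n2cc(-c3ccncc3)c(-c3ccc(Cl)c(O)c3)n2)c1)Nc1ccc(Cl)c(Cl)c1` gives only a limit of the assay, > 32500 nM.

Among the measured compounds shown here, in a functional assay on K562 cells (Homo sapiens) for inhibition, read by sulforhodamine B assay, with a stated time of 48 h (on this read-out higher numbers stand for weaker inhibition of growth and lower numbers for stronger inhibition of growth), compound 1 is the single compound with a real number, since the other two readings stop at a limit. Compound 2 reaches the limit > 50000 nM and no number. Compound 3 reaches the limit > 32500 nM and no number. For the measured compounds named here, no two of these measured compounds differ in only one place, so no measured step can be read off, and the two limits say only that compound 2 and compound 3 inhibit growth more weakly than a limit allows one to see.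

The unmeasured compound 4 `COc1cc(-c2nn(-c3cccc(NC(=O)Nc4cccc(C(F)(F)F)c4)c3)cc2-c2ccncc2)ccc1Cl` is the closest relative of compound 1. It differs in one place: hydrogen in place of trifluoromethyl on an aromatic carbon. Compound 1 carries two trifluoromethyl groups on that ring, compound 4 keeps one.

Going by the values given here, with no measured step to lean on, the expectation rests on compound 1 alone. The step is expected to be a 2.8-fold higher number from compound 1 to compound 4 (0.44 log units; beyond the scatter), a modest move toward weaker inhibition of growth, though a move within the scatter cannot be ruled out. Compound 4 is therefore estimated at 9000 nM, between 3000 nM and 40000 nM.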

Compound 4, concentration for total growth inhibition: > 50000 nM
Compound 4: a limit, no number; the forecaster's own chance of this, stated with the estimate: 25%; at least 5.5-fold (0.74 log units) between middle value and limit.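

In this assay, putting hydrogen in place of one trifluoromethyl group on an aromatic carbon gives an at least 15-fold higher number from compound 1 to compound 4 (1.18 log units; beyond the scatter) and this is the first readable step in the series, showing that this single position matters greatly: compound 1, with both trifluoromethyl groups on the ring, is the only compound shown that gives a real number. As far as these compounds go, the reading for compound 4 is a limit of the assay and not a number, so the true size of the step stays open on one side: the limit of > 50000 nM in this assay, at which 2 of the 4 values shown sit. The step between compound 2 and compound 4, which exchanges the (3-(trifluoromethyl)phenyl)amino group for 3-(trifluoromethyl)phenyl on a carbonyl carbon, cannot be read, since both of its readings are limits.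

The compounds shown do not tell whether the second trifluoromethyl group is needed as such, or whether another group on the same aromatic carbon, such as a nitrile, an amine or a carboxylic acid, would keep the growth inhibition of compound 1. They also leave open what removing the other trifluoromethyl group instead would do, and how much weaker compound 4 really is.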